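Thiosemicarbazone series: aryl to benzyl on the thioamide nitrogen

A few compounds are considered here, and "the series" means these few. Any claim that something is new, unique, unknown or untested is made for them only; others in the source may bear on it.

Compound 2 `Cc1cccc(NC(=S)N/N=C/c2ccc3ccccc3n2)c1` carries a 3-methylphenyl group on an amide-type nitrogen of the shared core. In a functional assay on SGC-7901 cells (Homo sapiens) for antiproliferative activity, read by sulforhodamine B assay, with a stated time of 72 h (on this read-out lower numbers stand for stronger inhibition and higher numbers for weaker inhibition), compound 2 gives > 100000 nM, which is a limit of the assay and not a number. Compound 1 `COc1ccccc1NC(=S)N/N=C/c1ccc2ccccc2n1` differs from compound 2 by 2-methoxyphenyl in place of 3-methylphenyl on that nitrogen; in this assay compound 1 gives > 100000 nM, again a limit. The step that the two limits leave unreadable from compound 1 to compound 2 therefore cannot be sized, since both values sit at the limit of > 100000 nM in this assay, at which 2 of the 2 values shown sit. Compound 3 `S=C(NCc1ccccc1)N/N=C/c1ccc2ccccc2n1` is still to be measured; it differs from compound 2 by benzyl in place of 3-methylphenyl on an amide-type nitrogen. For the measured compounds named here, no measured step bears directly on this change, and the only step at hand is unreadable, so neither direction nor size can be read from the series. Compound 3 is expected to sit near the limit as well, estimated at 100000 nM with a range from 30000 nM to 300000 nM. The expected step of a number no higher from compound 2 to compound 3 (the limit leaves the size open) is thus estimated to lie within the scatter.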

Compound 3, half-maximal inhibitory concentration: 53700 nM
Beside the measured number, compound 3's estimate is 1.9-fold (0.27 log units) above it, within the range that was stated.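

In this assay, benzyl on the amide-type nitrogen gives the first readable number at this position, while compound 1 and compound 2 both remain at a limit: the limit of > 100000 nM in this assay, at which 2 of the 3 values shown sit.

Against the two aryl groups, the change gives an at least 1.8-fold lower number from compound 2 to compound 3 (0.27 log units; that floor lies within the scatter) and an at least 1.8-fold lower number from compound 1 to compound 3 (0.27 log units; that floor lies within the scatter). Both are floors and not sizes, so the series shows only that benzyl and 3-methylphenyl, made of the same atoms joined differently, fall on the two sides of the limit, with no step yet shown beyond the scatter.

From the compounds shown here alone, the true size of both steps remains open, as does the unreadable step between the two aryl compounds. Also open, going by these compounds, is whether a longer chain such as 2-phenylethyl, or a plain ethyl group, on that nitrogen would move the number further from the limit or back to it.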